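From a Saturated to an Unsaturated Amide Chain

The source may hold more compounds than are shown below. What is called first, only, known or untested is meant among the compounds shown, and "the series" means these compounds.

compound 1, `CCCCC(=O)N(Cc1ccc(OC)c(O)c1)c1cc(OC)c(OC)c(OC)c1`, in a functional assay on MGC-803 cells (Homo sapiens) for inhibition, read by MTT assay, with a stated time of 48 h; a higher number here means a weaker inhibitor, a lower number a stronger inhibitor: 66 nM.
compound 2, `COc1cc(NCc2ccc(Cl)cc2)cc(OC)c1OC`, in this assay: the value is a limit of the assay, > 80000 nM.
compound 3, `COc1ccc(CNc2cc(OC)c(OC)c(OC)c2)cc1Br`, in this assay: 29400 nM.

Compound 1 holds the lowest of the two numbers in this assay; the nearest number, that of compound 3, lies far beyond the usual scatter. Compound 2 gives only a limit, as the line the limit of > 80000 nM in this assay, at which 1 of the 3 values shown sits, records. Within the data shown here, no pair among the measured compounds differs in a single place, so no measured step can guide a prediction.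

Compound 4, `CC/C=C/C(=O)N(Cc1ccc(OC)c(O)c1)c1cc(OC)c(OC)c(OC)c1`, is the untested compound. Compared with compound 1 it shows (but-1-en-1-yl in place of butyl on a carbonyl carbon). The carbonyl carbon keeps its attachment to the amide-type nitrogen; only the four-carbon chain gains its double bond.

Among the measured compounds shown here, with no measured step of this kind, the step from compound 1 to compound 4 in this assay is expected to be a 1.1-fold higher number from compound 1 to compound 4 (0.03 log units; within the scatter), not beyond the scatter. Compound 4 is therefore estimated at 70 nM, within a range from 20 nM to 250 nM.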

Compound 4, half-maximal inhibitory concentration: 58 nM
Beside the measured number, compound 4's estimate is 1.2-fold (0.08 log units) above it; measured number inside the range.
By their numbers in this assay, from the lowest: compounds 4 and 1 (each within the scatter of the next); then compound 3. At a limit, above all of these: compound 2.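

The earlier compounds shown here offered no measured step at this position, and compound 4 supplies the first. In this assay, but-1-en-1-yl in place of butyl on a carbonyl carbon gives a 1.1-fold lower number from compound 1 to compound 4 (0.06 log units; within the scatter) and so leaves the two compounds indistinguishable: for this pair, a double bond in the four-carbon chain makes no difference that can be read. Nothing in the data at hand bears on why the number holds across this change.

Going by these compounds, whether a longer chain, or a chain ending in an amine or a carboxylic acid, on the same carbonyl carbon would keep the number in this range remains open. This single step speaks only for these two chains, and no wider rule for the position can be drawn from it.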